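Isobutyl to Hydroxymethyl: Growth Inhibition Expected to Hold

A few compounds are considered here, and "the series" means these few. Any claim that something is new, unique, unknown or untested is made for them only; others in the source may bear on it.

Three compounds share one core and were each measured for growth inhibition. Compound 1 `O[C@H]1CO[C@H](COCc2ccccc2)[C@@H](OCc2ccccc2)[C@@H]1OCc1ccccc1` gives 37900 nM in a functional assay on HOS cells (Homo sapiens) for antiproliferative activity, read by sulforhodamine B assay; a lower number here means a stronger inhibitor of growth, a higher number a weaker inhibitor of growth. Compound 2 `CCCC[C@@H]1O[C@H](COCc2ccccc2)[C@@H](OCc2ccccc2)[C@H](OCc2ccccc2)[C@H]1O` gives 40100 nM in this assay, and compound 3 `CC(C)C[C@@H]1O[C@H](COCc2ccccc2)[C@@H](OCc2ccccc2)[C@H](OCc2ccccc2)[C@H]1O` gives 45200 nM in this assay. Compound 3 carries the highest of the three numbers, yet its gap to compound 2 and its gap to compound 1 are both within the scatter, so the three numbers cannot be ranked. Compound 4 `OC[C@@H]1O[C@H](COCc2ccccc2)[C@@H](OCc2ccccc2)[C@H](OCc2ccccc2)[C@H]1O` differs from compound 3 in one place: hydroxy in place of isopropyl on a saturated chain carbon bound to a saturated ring carbon. Going by the values given here, the steps that bear on this are a 1.1-fold higher number from compound 1 to compound 2 (0.02 log units; within the scatter), a 1.2-fold higher number from compound 1 to compound 3 (0.08 log units; within the scatter) and a 1.1-fold higher number from compound 2 to compound 3 (0.05 log units; within the scatter), none of them beyond the scatter; none of the measured steps brings in a hydroxy group, so the entering group has no precedent here. From these steps the account expects a 1.1-fold lower number from compound 3 to compound 4 (0.03 log units; within the scatter), with no step beyond the scatter. For compound 4 the estimated value in this assay is 42000 nM, expected to lie between 20000 nM and 90000 nM.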

Compound 4, concentration for 50% growth inhibition: 27300 nM
Compound 4: middle estimate off by 1.5-fold (0.19 log units), on the high side; low and high end bracket the measured number.
By their numbers in this assay, from the lowest: compounds 4, 1, 2 and 3 (each within the scatter of the next).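

In this assay, hydroxy in place of isopropyl on a saturated chain carbon bound to a saturated ring carbon gives a 1.7-fold lower number from compound 3 to compound 4 (0.22 log units; within the scatter), and the other two comparisons read alike, with a 1.5-fold lower number from compound 2 to compound 4 (0.17 log units; within the scatter) and a 1.4-fold lower number from compound 1 to compound 4 (0.14 log units; within the scatter). Going by these compounds alone, this is the first group at this position in the set to bring a hydrogen-bond donor and acceptor, and with hydroxymethyl there the number still cannot be told apart from those with hydrogen, butyl or isobutyl, so none of the four compounds can be ranked. No measurement is available that would explain this result.

As far as these compounds go, it remains open whether an amine, a carboxylic acid or a longer chain at this position would move the number beyond the scatter. The compounds shown also leave open whether any change elsewhere on the shared core, such as at the benzyl ethers, would do so.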